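The source may hold more compounds than are shown below. What is called first, only, known or untested is meant among the compounds shown, and "the series" means these compounds.

Working notes on the series in an assay on isolated protein for inhibition of Indoleamine 2,3-dioxygenase 1 (Homo sapiens), with a stated time of 60 min, tested at 10 uM; on this read-out lower numbers stand for less inhibition and higher numbers for more inhibition at the one concentration tested (going by the name of the read-out).

Three compounds share the same core and differ only in the group carried on the aromatic carbon. Compound 1 `Clc1ccc2[nH]c(SCc3ccccc3/C=C\c3ccccc3)nc2c1` gives 49% in this assay. Compound 2 `Clc1ccc2[nH]c(SCc3ccccc3C#Cc3ccccc3)nc2c1` gives 52%; the step of a number 3 percentage points higher from compound 1 to compound 2 (within the scatter) is within the scatter, so the two are not ordered. Compound 3 `Clc1ccc2[nH]c(SCc3ccccc3CCCc3ccccc3)nc2c1` gives 19%, the lowest of the three numbers: both steps to it, a number 30 percentage points lower from compound 1 to compound 3 (beyond the scatter) and a number 33 percentage points lower from compound 2 to compound 3 (beyond the scatter), are beyond the scatter, so compound 3 stands clearly apart from compounds 1 and 2.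

Compound 4 `Clc1ccc2[nH]c(SCc3ccccc3/C=C/c3ccccc3)nc2c1` is not yet measured. Its change from compound 3 is 2-phenylethenyl in place of 3-phenylpropyl on an aromatic carbon. The entering group is the same 2-phenylethenyl that compound 1 carries, so the measured step that bears most directly is the reverse of a number 30 percentage points lower from compound 1 to compound 3 (beyond the scatter), with a number 33 percentage points lower from compound 2 to compound 3 (beyond the scatter) pointing the same way. A rise of roughly that size is therefore expected, the step of a number 27 percentage points higher from compound 3 to compound 4 (beyond the scatter) in this assay being the estimate. Because compound 1 gives 49% with the same entering group, compound 4 is estimated at 46%, with an expected range of 26% to 66% in this assay.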

Compound 4, a percentage reported as inhibition, at one concentration (the size of the read-out at that concentration, not a potency): -6%
For compound 4 the middle estimate is 52 percentage points above the measured one; the measured number lies below the stated range.
By their numbers in this assay, from the lowest: compound 4; then compound 3; then compounds 1 and 2 (each within the scatter of the next).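

The configuration of the double bond, and not only the identity of the group, governs the read-out at this position in this assay, and the size of a number 55 percentage points lower from compound 1 to compound 4 (beyond the scatter) can be assigned to that configuration alone because nothing else differs: the fact that compounds 1 and 4 differ only in the configuration as drawn. The 2-phenylethenyl group drawn E in compound 4 also falls short of both other groups, as shown by a number 25 percentage points lower from compound 3 to compound 4 (beyond the scatter) and a number 58 percentage points lower from compound 2 to compound 4 (beyond the scatter), so the name 2-phenylethenyl alone is not enough to place a compound in this short series. An unsaturated link on this aromatic carbon therefore does not in itself go with the higher numbers: compounds 1 and 2 fit that reading, and compound 4 goes against it.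

Why the two double-bond configurations part so widely stays open, as does whether the same gap would persist with an amine or a carboxylic acid on the phenyl ring of the 2-phenylethenyl group. It is also open how a shorter chain such as benzyl or a longer chain such as 4-phenylbutyl would stand against compound 3, and the single tested concentration gives no potency for any of these compounds.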